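A few compounds are considered here, and "the series" means these few. Any claim that something is new, unique, unknown or untested is made for them only; others in the source may bear on it.

Compound 2 `COc1ccc(N2C(=O)C(C)(C)c3cccnc32)cc1` gives 42% in a functional assay on the whole organism (Pleural cavity) for inhibition, with Rattus norvegicus as the target, at a dose of 25 mg/kg (a higher number here means more inhibition at the dose given (going by the name of the read-out), a lower number less inhibition), the highest of the three numbers recorded. Compound 1 `CC1(C)C(=O)N(c2ccc(S(C)(=O)=O)cc2)c2ncccc21` gives 0% in this assay, and the change from compound 1 to compound 2, methoxy in place of methylsulfonyl on an aromatic carbon, produced a number 42 percentage points higher from compound 1 to compound 2 (beyond the scatter). Compound 3 `CC1(Cc2ccccc2)C(=O)N(c2ccccc2)c2ncccc21` gives 0% in this assay. Compound 4 `CSc1ccc(N2C(=O)C(C)(C)c3cccnc32)cc1` differs from compound 2 by methylsulfanyl in place of methoxy on an aromatic carbon. Going by the values given here, the one step that bears on it is the swap at the same ring position, which was large, so a change at this place can matter; with only that step as a guide, a moderate fall from compound 2 to compound 4 is expected, a number 12 percentage points lower from compound 2 to compound 4 (beyond the scatter). Compound 4 is therefore estimated at 30%, in the range 5% to 55%.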

Compound 4, a percentage reported as inhibition, in the whole organism at one dose (the size of the read-out at that dose, not a potency): 37%
Compound 4: the middle estimate sits 7 percentage points below what was measured, and the stated range covers the measured number.
By their numbers in this assay, from the lowest: compounds 1 and 3 (each within the scatter of the next); then compounds 4 and 2 (each within the scatter of the next).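

Methylsulfanyl in place of methoxy gave a number 5 percentage points lower from compound 2 to compound 4 (within the scatter) in this assay, so at this place, para to a large group, these two groups cannot be told apart. Methylsulfanyl in place of methylsulfonyl gave a number 37 percentage points higher from compound 1 to compound 4 (beyond the scatter), so a second group now shows a large step from compound 1 at the same place. No measurement bearing on the reason accompanies these results.

As far as these compounds go, whether an amine, a chlorine atom or a longer chain such as ethoxy at this position would fit with methoxy and methylsulfanyl or with methylsulfonyl remains open.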